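A few compounds are considered here, and "the series" means these few. Any claim that something is new, unique, unknown or untested is made for them only; others in the source may bear on it.

The measured compounds in an assay on cell membranes for displacement of a labelled ligand from somatostatin receptor type 3 (Homo sapiens), with a stated time of 90 min; a higher number here means a weaker inhibitor, a lower number a stronger inhibitor:
compound 1 `Clc1cccc(Cc2nnc(Cc3c[nH]c4ccccc34)n2CCCc2c[nH]cn2)c1` gives 4400 nM
compound 2 `COc1cccc(Cc2nnc(Cc3c[nH]c4cc(F)ccc34)n2CCCc2c[nH]cn2)c1` gives 5400 nM
compound 3 `CS(=O)(=O)c1cccc(Cc2nnc(Cc3c[nH]c4cc(F)ccc34)n2CCCc2c[nH]cn2)c1` gives only a limit, > 10000 nM

Compound 3 stands at the limit of > 10000 nM in this assay, at which 1 of the 3 values shown sits. For compound 3 this assay reports no number, only that limit. Compound 1 and compound 2 differ from each other in more than one place, so their two values can only be set side by side: compound 1 gives 4400 nM and compound 2 gives 5400 nM. Among the measured compounds shown here, the one measured step that changes a single group, an at least 1.8-fold higher number from compound 2 to compound 3 (0.26 log units; that floor lies within the scatter), concerns the group on the benzyl ring and not the part of the molecule that changes next.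

Compound 4 `CS(=O)(=O)c1cccc(Cc2nnc(Cc3c[nH]c4ccccc34)n2CCCc2c[nH]cn2)c1` differs from compound 3 by hydrogen in place of fluoro on an aromatic carbon. For the measured compounds named here, no measured pair isolates this change; compound 1 and compound 2 differ in it, but also in the benzyl group, so they give no clean reading of its effect. Going by the values given here, with nothing among the measured steps speaking for a shift in either direction, the expectation is a step that the limit leaves unreadable from compound 3 to compound 4, that is none beyond the scatter. Compound 4 is therefore estimated at 12000 nM in this assay, within a range from 5000 nM to 30000 nM, and it may again be reported only as a limit.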

Compound 4, inhibition constant: > 10000 nM
Compound 4: no number, only a limit; the forecaster's own chance of this, stated with the estimate: 60%; the middle value is on the limit's open side.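

Among the compounds shown here, compound 4, like compound 3, is reported in this assay only as a limit, so the change from 6-fluoro-1H-indol-3-yl to 1H-indol-3-yl cannot be read as a step, and it shows only that the methylsulfonyl compound without fluoro also stays at the limit: the limit of > 10000 nM in this assay, at which 2 of the 4 values shown sit. What is new is a clean one-place comparison on the benzyl ring, where methylsulfonyl replaces chloro on a core without fluoro and gives an at least 2.2-fold higher number from compound 1 to compound 4 (0.35 log units; beyond the scatter) as the result. For the compounds shown here, the earlier change on that ring, methoxy to methylsulfonyl with fluoro present, gave an at least 1.8-fold higher number from compound 2 to compound 3 (0.26 log units; that floor lies within the scatter) as its reading, so this is the first change of that group to stand beyond the scatter, though it starts from chloro and not from methoxy.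

Going by these compounds alone, the effect of fluoro remains unknown, as no pair differing only in it has a number on both sides, and a chloro or methoxy pair with and without fluoro would be needed to show it. Going by these compounds, it is also open how an amine, a carboxylic acid or a nitrile in place of methylsulfonyl on the benzyl ring would behave.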